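The source may hold more compounds than are shown below. What is called first, only, known or untested is meant among the compounds shown, and "the series" means these compounds.

The three measured compounds share one core, and compound 2 is `Cc1cccc(NC(=O)CSC(=S)N[C@H]2CCOC2=O)c1`. In a functional assay on EC9706 cells (Homo sapiens) for cytotoxicity, read by MTT assay, with a stated time of 72 h (on this read-out lower numbers stand for stronger inhibition and higher numbers for weaker inhibition), compound 2 gives only a limit of the assay, > 128000 nM. Compound 1, `Cc1cccc(NC(=O)CSC(=S)N[C@H]2CCOC2=O)c1C`, likewise returns only a limit, > 128000 nM. Compound 3, `O=C(CSC(=S)N[C@H]1CCOC1=O)Nc1ccccc1Cl`, also stops at a limit, > 128000 nM. Taken together, (the limit of > 128000 nM in this assay, at which 3 of the 3 values shown sit). The step from compound 1 to compound 2 is a step that the two limits leave unreadable from compound 1 to compound 2, and the step from compound 2 to compound 3 is a step that the two limits leave unreadable from compound 2 to compound 3; neither can be read in size or in direction.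

Compound 4 is `O=C(CSC(=S)N[C@H]1CCOC1=O)Nc1cccc(C(F)(F)F)c1`. It differs from compound 2 by trifluoromethyl in place of methyl on an aromatic carbon. With both measured steps on this core unreadable, nothing points to a gain or a loss for compound 4 in this assay, and the expectation is that compound 4 too stays at a limit. The step from compound 2 to compound 4 is expected to be a step that the limit leaves unreadable from compound 2 to compound 4. Compound 4 is estimated at 150000 nM, within a range from 60000 nM to 400000 nM.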

Compound 4, half-maximal inhibitory concentration: 79700 nM
For compound 4 the middle estimate is 1.9-fold (0.27 log units) above the measured one, and the stated range covers the measured number.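

Among these compounds, compound 4 is the first compound on the shared core to return a number rather than a limit in this assay, so trifluoromethyl in place of methyl on this aromatic carbon, meta to a large group, gives the first readable step: an at least 1.6-fold lower number from compound 2 to compound 4 (0.20 log units; that floor lies within the scatter). Since that floor lies within the scatter, the step on its own does not establish a real gain, though it does show that this position can carry a change that brings a value into the readable range. The other compounds on this core stay where they were: the limit of > 128000 nM in this assay, at which 3 of the 4 values shown sit.

On these data alone, the true size of the step remains open, since compound 2 has only a limit. Also open, as far as these compounds go, is what an amine or a carboxylic acid in place of methyl on this aromatic carbon would give in this assay.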